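A mirror-image partner for compound 1

This account rests on a few compounds, and the source may have more. Where it says the series, first, only, none or still open, it means among the compounds named here.

Values in a physicochemical assay for solubility, measured as kinetic solubility (a lower number here means a less soluble compound, a higher number a more soluble compound), are these:
- compound 1 `Cc1cc(C)c(CN2CCc3c(Cl)cc([C@H](CO)[C@H]4CCCO4)c(Cl)c3C2=O)c(=O)[nH]1` gives 430000 nM
- compound 2 `Cc1cc(C)c(CN2CCc3c(Cl)cc(C(CO)c4ccon4)c(Cl)c3C2=O)c(=O)[nH]1` gives 596000 nM; 481000 nM (2 entries)
- compound 3 `COC(c1cc(Cl)c2c(c1Cl)C(=O)N(Cc1c(C)cc(C)[nH]c1=O)CC2)C1CCS(=O)(=O)CC1` gives 373000 nM; 415000 nM (2 entries)

Compound 1 at 430000 nM lies within the usual scatter of both other compounds, so the three cannot be ranked. Repeat measurements show how much one compound can vary, as in the several entries of compound 2 in this assay, 596000 nM; 481000 nM (2 entries) and in the several entries of compound 3 in this assay, 373000 nM; 415000 nM (2 entries) for a sense of that noise.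

Compound 4 `Cc1cc(C)c(CN2CCc3c(Cl)cc([C@@H](CO)[C@@H]4CCCO4)c(Cl)c3C2=O)c(=O)[nH]1` has not been measured yet. Its difference from compound 1 is this: the two compounds have the same atoms and bonds and differ only in configuration as drawn: 2 of 2 stereo elements differ (all stereocentres are inverted: mirror images); a stereocentre at a saturated chain carbon is drawn R in compound 1 and S in compound 4; a stereocentre at a saturated ring carbon is drawn R in compound 1 and S in compound 4 and so the two are mirror images. For the measured compounds named here, no measured pair here differs in one place only, which leaves no step to serve as a guide. No step beyond the scatter is expected in this assay in either direction. The expectation stays anchored on compound 1 at 430000 nM and nothing in the data moves it up or down. The expected change, no change at the digits printed from compound 1 to compound 4 (within the scatter) and no more, stays inside that scatter. In this assay the estimate for compound 4 is 430000 nM with 270000 nM to 650000 nM as its expected range.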

Compound 4, solubility: 550000 nM
Beside the measured number, compound 4's estimate is 1.3-fold (0.11 log units) below it; the range from low to high includes it.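

For the compounds shown here, this pair gives the first step in this assay that can be read directly, a 1.3-fold higher number from compound 1 to compound 4 (0.11 log units; within the scatter). At this position, turning both the saturated chain carbon and the saturated ring carbon from R to S leaves the value inside the scatter, so the two mirror images cannot be ranked. The gap between them is of the same kind as the spread between repeat entries of a single compound: the several entries of compound 2 in this assay, 596000 nM; 481000 nM (2 entries)

From the compounds shown here alone, both stereocentres change together here, so it stays open what inverting only the chain carbon or only the ring carbon would do. Also open, going by these compounds, is whether a group of another kind on this side chain, such as an amine or a carboxylic acid, would move the number beyond the scatter.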